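Pyrrole acids against NOTUM: from methyl to tert-butyl

This account rests on a few compounds, and the source may have more. Where it says the series, first, only, none or still open, it means among the compounds named here.

Measured so far:
compound 1 `Cc1[nH]c(C(F)(F)F)cc1C(=O)O`: 6700 nM
compound 2 `Cc1cccc(-n2c(C)cc(C(=O)O)c2C)c1`: 1500 nM

Of the compounds shown here, two have been tested in an assay on cells for inhibition of Palmitoleoyl-protein carboxylesterase NOTUM variant C330S (Homo sapiens), read by fluorescence, with a stated time of 40 min; a lower number here means a stronger inhibitor, a higher number a weaker inhibitor. Compound 1 gives 6700 nM in this assay, while compound 2 gives 1500 nM in this assay and therefore stands as the lower of the two numbers, its gap to compound 1 lying beyond the scatter. The two differ in more than one place, so their values are only set side by side here.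

Compound 3 `Cc1cc(C(=O)O)c(C)n1-c1cccc(C(C)(C)C)c1` is the next compound to be run in this assay. It follows from compound 2 by a single change: tert-butyl in place of methyl on an aromatic carbon. The new group sits on an aromatic carbon of a six-membered aromatic ring of carbon only, meta to a large group.

Among the compounds with values here, no pair of measured compounds differing in one place exists in this set, so the size of the step is open. The author expects a modest gain in this assay, a step of about a 1.9-fold lower number from compound 2 to compound 3 (0.27 log units; within the scatter). For compound 3 the estimate in this assay is 800 nM, with a range from 250 nM to 3000 nM.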

Compound 3, half-maximal inhibitory concentration: 460 nM
Compound 3: middle estimate off by 1.7-fold (0.24 log units), on the high side; low and high end bracket the measured number.
By their numbers in this assay, from the lowest: compound 3; then compound 2; then compound 1.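

Within the data shown here, replacing methyl with tert-butyl gives a 3.3-fold lower number from compound 2 to compound 3 (0.51 log units; beyond the scatter) in this assay and provides the first single-place comparison in this set. It shows that, at this aromatic carbon meta to a large group, a substituent of 4 heavy atoms in place of 1 heavy atom is compatible with a lower number, and the series gains rather than loses inhibition with this change. No measurement on hand accounts for the gain.

With only methyl and tert-butyl compared at this carbon, the compounds shown cannot tell whether the number depends on the size of the group or on something particular to tert-butyl. On these data alone, it remains open how an isopropyl group, a chlorine atom, a methoxy group or a carboxylic acid would fare at the same place.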